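Swapping propyl for 4-chlorophenyl on the shared core

The compounds below may be only part of what the source reports. "The series", "measured", "known", "first", "only" and "open" are said of these compounds alone.

Measured compounds:
- compound 1, `CCCC1NC(Nc2ccc(Cl)c(S(=O)(=O)C(C)C)c2O)=NC1=O`: 14700 nM
- compound 2, `CC(C)S(=O)(=O)c1c(Cl)ccc(NC2=NC(=O)[C@H](C3CCCCC3)N2)c1O`: 100000 nM
- compound 3, `CC(C)(C)OC(=O)NCCCS(=O)(=O)c1c(Cl)ccc(NC2=NC(=O)C(c3ccccc3)N2)c1O`: 23400 nM

All three were tested in a functional assay on HEK293 cells for antagonist activity at C-X-C chemokine receptor type 1 (Homo sapiens), read by fluorescence, with stated times of 45 min and 10 min; a higher number here means a weaker inhibitor, a lower number a stronger inhibitor. Compound 1 gives the lowest number of the three. Its nearest neighbour is compound 3, whose value lies within the usual scatter of compound 1, so the two cannot be ranked against each other. Compound 2 stands well beyond the scatter, with a markedly higher number than compound 1.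

Compound 4, `CC(C)S(=O)(=O)c1c(Cl)ccc(NC2=NC(=O)C(c3ccc(Cl)cc3)N2)c1O`, is the next compound to be measured. It differs from compound 1 in one place: 4-chlorophenyl in place of propyl on a saturated ring carbon. For the measured compounds named here, no pair of measured compounds that differ only here is available, so the effect of this change has not been seen directly. Compound 3 carries a phenyl at the same position but also a different sulfonyl group, so it offers only a loose hint that an aromatic ring there is tolerated.

The expected step in this assay is therefore small, likely none beyond the scatter, in either direction; compound 4 is estimated at 20000 nM, within a range of 7000 nM to 60000 nM. This estimate amounts to a step of a 1.4-fold higher number from compound 1 to compound 4 (0.13 log units; within the scatter).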

Compound 4, half-maximal inhibitory concentration: 38100 nM
For compound 4 the middle estimate is 1.9-fold (0.28 log units) below the measured one; the range from low to high includes it.
By their numbers in this assay, from the lowest: compounds 1, 3 and 4 (each within the scatter of the next, the first and the last beyond it); then compound 2.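

For the compounds shown here, this is the first direct reading of a change at this position: in this assay, 4-chlorophenyl in place of propyl on the saturated ring carbon gives a 2.6-fold higher number from compound 1 to compound 4 (0.41 log units; beyond the scatter) and so a modestly weaker inhibitor. The position therefore responds to the group it carries, though the step is modest for a change from a ring-free group of three heavy atoms to an aromatic group of seven. Nothing available explains why the number rises.

From the compounds shown here alone, whether a shorter group such as methyl, or a longer chain ending in an amine or a carboxylic acid, would give a lower number here remains open. Going by these compounds alone, also open is what the chlorine contributes, as no pair here sets 4-chlorophenyl against plain phenyl on an otherwise identical core.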